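Changing the aryl ring of the ester on a shared core

A few compounds are considered here, and "the series" means these few. Any claim that something is new, unique, unknown or untested is made for them only; others in the source may bear on it.

Three compounds on one shared core differ only in the aromatic ring attached to the carbonyl carbon of the ester. In a functional assay, with a stated time of 30 min (on this read-out lower numbers stand for stronger inhibition and higher numbers for weaker inhibition), compound 1 `COc1ccc(C2CC(=NOC(=O)c3ccccc3)CC(c3ccc(OC)cc3)N2C)cc1` gives 375000 nM. Compound 2 `COc1ccc(C2CC(=NOC(=O)c3ccc(F)cc3)CC(c3ccc(OC)cc3)N2C)cc1` gives 152000 nM, and compound 3 `COc1ccc(C2CC(=NOC(=O)c3cc([N+](=O)[O-])cc([N+](=O)[O-])c3)CC(c3ccc(OC)cc3)N2C)cc1` gives 312000 nM. Among these numbers compound 3 holds the second highest, sitting close to compound 1 and further from compound 2, as a 2.1-fold higher number from compound 2 to compound 3 (0.31 log units; beyond the scatter) shows.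

Compound 4 `COc1ccc(C2CC(=NOC(=O)c3cccc(O)c3)CC(c3ccc(OC)cc3)N2C)cc1` is the next step: 3-hydroxyphenyl in place of 3,5-dinitrophenyl on a carbonyl carbon. For the measured compounds named here, two measured steps bear on a swap at this ring. The step of a 1.2-fold lower number from compound 1 to compound 3 (0.08 log units; within the scatter) was within the scatter, and the step of a 2.1-fold higher number from compound 2 to compound 3 (0.31 log units; beyond the scatter) was only modest, as was a 2.5-fold lower number from compound 1 to compound 2 (0.39 log units; beyond the scatter). Every change tried so far at this ring has moved this assay little, so a new ring here is expected to do the same.

Compound 4 is therefore expected to give about 300000 nM, with a likely range from 120000 nM to 750000 nM. That estimate amounts to an expected 1.0-fold lower number from compound 3 to compound 4 (0.02 log units; within the scatter), a step not expected to pass beyond the scatter.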

Compound 4, half-maximal inhibitory concentration: 34000 nM
Estimate against measurement, compound 4: 8.8-fold (0.95 log units) above; the whole stated range lies above it.
By their numbers in this assay, from the lowest: compound 4; then compound 2; then compounds 3 and 1 (each within the scatter of the next).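

In this assay, for the compounds shown here, this ring proved more sensitive than the first three compounds suggested: the addition of a hydroxy group to the plain phenyl ring gives an 11-fold lower number from compound 1 to compound 4 (1.04 log units; beyond the scatter) and is the only step at this ring to be rated large. The 3-hydroxyphenyl ring also stands apart from the two substituted rings, with a 9.2-fold lower number from compound 3 to compound 4 (0.96 log units; beyond the scatter) and a 4.5-fold lower number from compound 2 to compound 4 (0.65 log units; beyond the scatter) both beyond the scatter, which makes compound 4 the strongest inhibitor of the four in this set. Among these rings, only 3-hydroxyphenyl carries a hydrogen-bond donor, but this is a difference in counted features, and no measurement here explains the drop in the number.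

The compounds shown cannot tell whether the hydroxy group itself is needed, since no close replacement such as a methoxy group, an amine or a carboxylic acid appears at that place on the ring. They also leave open whether 4-hydroxyphenyl or 3,5-dihydroxyphenyl would match, exceed or fall short of the 3-hydroxyphenyl ring.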